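The compounds below may be only part of what the source reports. "The series", "measured", "known", "first", "only" and "open" are said of these compounds alone.

Working notes on the series, read in a functional assay on Calu-1 cells (Homo sapiens) for cytotoxicity, read by resazurin assay, with a stated time of 72 h; on this read-out lower numbers stand for stronger inhibition and higher numbers for weaker inhibition. Compound 1 `COc1cc(/C=C/C(=O)OCCCCCCO[N+](=O)[O-])ccc1O` gives > 50000 nM, which is a limit of the assay and not a number. For the measured compounds named here, compound 2 `O=C(/C=C/c1ccc(O)c(O)c1)OCc1c(-c2ccccc2)no[n+]1[O-]` gives 7680 nM in this assay, and this is the only true number so far, with no other measured number to rank it against.

Compound 3 `COc1cc(/C=C/C(=O)OCc2c(-c3ccccc3)no[n+]2[O-])ccc1O` has not yet been measured. It differs from compound 2 by methyl in place of hydrogen on an oxygen on an aromatic ring, which turns 3,4-dihydroxyphenyl into 4-hydroxy-3-methoxyphenyl. Going by the values given here, no measured pair isolates this change, so its size in this assay can only be expected. Among the compounds with values here, the sole hint comes from compound 1, which carries the same 4-hydroxy-3-methoxyphenyl group and gives > 50000 nM, again a limit, though it also differs from compound 2 elsewhere.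

A modest weakening is therefore expected, near the edge of the usual scatter, and the expected move is a 2.1-fold higher number from compound 2 to compound 3 (0.32 log units; beyond the scatter). Compound 3 is estimated at 16000 nM, with an expected range of 6000 nM to 45000 nM.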

Compound 3, half-maximal inhibitory concentration: 22900 nM
Beside the measured number, compound 3's estimate is 1.4-fold (0.16 log units) below it; the measured number falls inside the stated range.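

The hydroxy to methoxy change now has a measured size in this assay, with a 3.0-fold higher number from compound 2 to compound 3 (0.47 log units; beyond the scatter). Methyl in place of hydrogen on this oxygen therefore costs activity on the shared core, yet the 4-hydroxy-3-methoxyphenyl group in compound 3 still gives a true number and not a limit, so this group alone does not carry a compound out of the measurable range. For the compounds shown here, compound 1, which has the same 4-hydroxy-3-methoxyphenyl group on a different ester side, remains the only compound at a limit, and that entry is not a number: the limit of > 50000 nM in this assay, at which 1 of the 3 values shown sits.

As far as these compounds go, whether the same change costs a similar amount on another ester side stays open, as this is a single step on a single core, and the effect of the ester side cannot be sized from a limit. Also open, from the compounds shown here alone, is how this oxygen would read with a longer chain such as ethyl in place of methyl, or how the aromatic ring would read with an amine or a carboxylic acid in place of the hydroxy group.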